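This account rests on a few compounds, and the source may have more. Where it says the series, first, only, none or still open, it means among the compounds named here.

Compound 1 `COc1ccccc1/C=C/c1cccc(O)c1` and compound 3 `COc1ccccc1/C=C/c1cccc(N)c1` share one core and differ in a single spot: amino in place of hydroxy on an aromatic carbon. In a functional assay on MCF7 cells (Homo sapiens) for inhibition, read by MTT assay, with a stated time of 2 days (a lower number here means a stronger inhibitor, a higher number a weaker inhibitor), compound 1 gives 24.3 ug/mL, while in this assay compound 3 gives 38.7 ug/mL. Going from one to the other, the measured step was a 1.6-fold higher number from compound 1 to compound 3 (0.20 log units; within the scatter), so the swap of hydroxy for amino left the result essentially where it had been.

Compound 2 `COc1ccc(/C=C/c2cccc(O)c2)cc1` is built from the same atoms as compound 1, joined differently; the difference between the two cores is not broken down here. In this assay compound 2 gives 21 ug/mL, a number lying within the scatter of both compound 1 and compound 3.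

Compound 4 `COc1ccc(/C=C/c2cccc(N)c2)cc1` stands to compound 2 exactly as compound 3 stands to compound 1: amino in place of hydroxy on an aromatic carbon, the same change at the same kind of position. The expected step is a 1.6-fold higher number from compound 2 to compound 4 (0.20 log units; within the scatter), matching the earlier one because a 1.6-fold higher number from compound 1 to compound 3 (0.20 log units; within the scatter) lay within the scatter, and because compound 2 gives 21 ug/mL, so near what compound 1 gave. Compound 4 is therefore estimated at 33 ug/mL, expected to fall between 17 ug/mL and 65 ug/mL.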

Compound 4, half-maximal inhibitory concentration: 23 ug/mL
Estimate against measurement, compound 4: 1.4-fold (0.16 log units) above, within the range that was stated.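

On the core of compound 2, amino in place of hydroxy gave a 1.1-fold higher number from compound 2 to compound 4 (0.04 log units; within the scatter) in this assay, so here too the swap left the result essentially where it had been. Set side by side, the two steps do not differ by more than repeated measurements would, and the change carried over from one core to the other without a visible difference: the same change on two cores in this assay, a 1.6-fold higher number (0.20 log units; within the scatter) from compound 1 to compound 3 and a 1.1-fold higher number (0.04 log units; within the scatter) from compound 2 to compound 4, 1.5-fold (0.16 log units) apart, within the scatter of two such steps.

Among the compounds shown here, this shows only that the swap produced no step beyond the scatter on these two closely related cores; with steps this small, it does not establish a real shared effect of the change, and it says nothing about cores of a different kind or about other assays.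

The compounds shown leave open whether a different group on that aromatic carbon, such as a carboxylic acid, a nitrile or an acetamide, would move the number beyond the scatter. Also open, going by these compounds, is whether the swap would behave the same way with an ethoxy or a chlorine in place of the methoxy.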